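The compounds below may be only part of what the source reports. "The series", "measured", "known", "first", "only" and "open" are said of these compounds alone.

Measured compounds:
compound 1 `COc1cc(-c2ccnc3cc(-c4cccc(C#N)c4)nn23)cc(OC)c1OC` gives > 10000 nM
compound 2 `COc1cc(-c2ccnc3cc(-c4ccccc4)nn23)cc(OC)c1OC` gives 3880 nM

In a functional assay on HCT-116 cells (Homo sapiens) for inhibition, read by CCK-8 assay, with a stated time of 48 h (a lower number here means a stronger inhibitor, a higher number a weaker inhibitor), compound 1 reaches only a limit, not a number, as shown by the limit of > 10000 nM in this assay, at which 1 of the 2 values shown sits. Compound 2 gives 3880 nM in this assay. Going by the values given here, the one step measured so far, an at least 2.5-fold lower number from compound 1 to compound 2 (0.41 log units; beyond the scatter), shows that taking the cyano away from the aromatic ring lowers the number at least modestly.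

Compound 3 `COc1ccc(-c2cc3nccc(-c4cc(OC)c(OC)c(OC)c4)n3n2)cc1N` is not yet measured. It differs from compound 1 as follows: 3-amino-4-methoxyphenyl in place of 3-cyanophenyl on an aromatic carbon. Among the compounds with values here, only the step from compound 1 to compound 2 bears on this change, since it likewise removes the 3-cyanophenyl's nitrile, but here an amino and a methoxy enter in its place, on which no measured step speaks. Compound 3 is therefore expected to lie somewhere between the limit of compound 1 and the number for compound 2, with the step of an at least 1.6-fold lower number from compound 1 to compound 3 (0.22 log units; that floor lies within the scatter) estimated downward, and its value is estimated at 6000 nM, between 2000 nM and 18000 nM.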

Compound 3, half-maximal inhibitory concentration: 251 nM
Compound 3: middle estimate off by 24-fold (1.38 log units), on the high side; measured number outside the range, below it.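

Compared with the earlier compounds, which showed only that losing the nitrile from 3-cyanophenyl lowers the number, compound 3 shows that on this aromatic carbon of the five-membered aromatic ring a substituted phenyl can lower it much further in this assay. Replacing phenyl with 3-amino-4-methoxyphenyl gives a 15-fold lower number from compound 2 to compound 3 (1.19 log units; beyond the scatter), so a substituent on this ring does not always go with a higher number, as the nitrile does in compound 1. Replacing 3-cyanophenyl with 3-amino-4-methoxyphenyl gives an at least 39-fold lower number from compound 1 to compound 3 (1.60 log units; beyond the scatter), and this size is only a floor because compound 1 reaches a limit and not a number: the limit of > 10000 nM in this assay, at which 1 of the 3 values shown sits.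

On these data alone, the amino and the methoxy enter together, so what each contributes alone remains open. As far as these compounds go, whether a hydroxyl or an acetamide in place of the amino would keep the number this low is also open.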